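A Hydrazone Arm Without Its Carbonyl

The compounds below may be only part of what the source reports. "The series", "measured", "known", "first", "only" and "open" are said of these compounds alone.

Three compounds share one core and differ at a single arm. In a functional assay on KB cells (Homo sapiens) for cytotoxicity, read by spectrophotometry and crystal violet staining (on this read-out higher numbers stand for weaker inhibition and lower numbers for stronger inhibition), compound 1 `CC(=O)N/N=C/c1c(Cl)n(C2O[C@H](CO)[C@@H](O)[C@H]2O)c2cc(Cl)c(Cl)cc12` gives 9000 nM. Compound 2 `COC(=O)N/N=C/c1c(Cl)n(C2O[C@H](CO)[C@@H](O)[C@H]2O)c2cc(Cl)c(Cl)cc12` gives 20000 nM, and compound 3 `NC(=O)c1c(Cl)n(C2O[C@H](CO)[C@@H](O)[C@H]2O)c2cc(Cl)c(Cl)cc12` gives 45000 nM. Compound 2 thus stands second highest of the three, set by a 2.2-fold higher number from compound 1 to compound 2 (0.35 log units; beyond the scatter) and a 2.3-fold higher number from compound 2 to compound 3 (0.35 log units; beyond the scatter). Compound 4 `CN(C)/N=C/c1c(Cl)n(C2O[C@H](CO)[C@@H](O)[C@H]2O)c2cc(Cl)c(Cl)cc12` carries dimethylamino in place of (methoxycarbonyl)amino on a double-bonded nitrogen. For the measured compounds named here, no measured step strips the carbonyl from this arm in that way; the nearest are a 2.2-fold higher number from compound 1 to compound 2 (0.35 log units; beyond the scatter), a swap of methoxy for methyl, and a 5.0-fold higher number from compound 1 to compound 3 (0.70 log units; beyond the scatter), an exchange of the whole arm for a smaller group. Both are modest, so only a modest step is expected, leaning toward a lower number, a 2.0-fold lower number from compound 2 to compound 4 (0.30 log units; within the scatter). Compound 4 is estimated at 10000 nM, between 3000 nM and 40000 nM.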

Compound 4, half-maximal inhibitory concentration: 70000 nM
Estimate against measurement, compound 4: 7.0-fold (0.85 log units) below, and the stated range ends below it.
By their numbers in this assay, from the lowest: compound 1; then compound 2; then compounds 3 and 4 (each within the scatter of the next).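

In this assay, dimethylamino on the double-bonded nitrogen gave a 3.5-fold higher number from compound 2 to compound 4 (0.54 log units; beyond the scatter) and, against the acetamido arm, a 7.8-fold higher number from compound 1 to compound 4 (0.89 log units; beyond the scatter) as the widest step among these compounds, so keeping the arm while losing its carbonyl did not lower the number. With a 1.6-fold higher number from compound 3 to compound 4 (0.19 log units; within the scatter) as the remaining step, the dimethylamino arm cannot be told apart from the short arm of compound 3. Nothing available accounts for this rise. Still open, on these data alone, is whether a plain amino group on this nitrogen, or a longer alkyl chain on the carbonyl, would keep the number near that of compound 1.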